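Naphthalene in place of methylindole: an untested step

The compounds below may be only part of what the source reports. "The series", "measured", "known", "first", "only" and "open" are said of these compounds alone.

Measured so far:
Compound 1 `COc1ccc2nccc(C3CN(CCCNCc4cc5ccccc5[nH]4)C(=O)O3)c2c1`, which in an in vitro functional assay on RBL cells for antagonist activity at C-C chemokine receptor type 8 (Homo sapiens), read by FLIPR and calcium flux (on this read-out lower numbers stand for stronger inhibition and higher numbers for weaker inhibition), gives 1580 nM.
Compound 2 `O=C1OC(c2cnc3ccccc3c2)CN1C1CCN(Cc2cc3ccccc3[nH]2)CC1`, for which this assay reports only a limit, < 50200 nM.
Compound 3 `COc1ccc2nccc(C3CN(C4CCN(Cc5cc6ccccc6n5C)CC4)C(=O)O3)c2c1`, which in this assay gives 3160 nM.

Only two of the three results are actual numbers; the third is the limit of < 50200 nM in this assay, at which 1 of the 3 values shown sits, so it cannot be ranked against the others. Of the two numbers, compound 3 carries the higher one, but its gap to compound 1 lies within the usual scatter of repeated measurements, so the two cannot be told apart on these data. Among the measured compounds shown here, no two of the measured compounds differ in a single place, so there is no measured step to lean on.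

Compound 4 `COc1ccc2nccc(C3CN(C4CCN(Cc5ccc6ccccc6c5)CC4)C(=O)O3)c2c1` is the next compound to be tested. It differs from compound 3 in one place: naphthalen-2-yl in place of 1-methyl-1H-indol-2-yl on a saturated chain carbon bound to an amine nitrogen in a ring. The group that leaves has one hydrogen-bond acceptor; the group that enters has none, and both have the same count of heavy atoms.

For the measured compounds named here, with no measured step of this kind, the expectation for compound 4 is a small step, a 1.6-fold higher number from compound 3 to compound 4 (0.20 log units; within the scatter), that may fall within the scatter. Compound 4 is therefore estimated at 5000 nM, somewhere between 1500 nM and 16000 nM.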

Compound 4, half-maximal inhibitory concentration: 1260 nM
Beside the measured number, compound 4's estimate is 4.0-fold (0.60 log units) above it; the measured number lies below the stated range.
By their numbers in this assay, from the lowest: compounds 4, 1 and 3 (each within the scatter of the next, the first and the last beyond it).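

In this assay, among the compounds shown here, this is the first change in a single place to be measured, and it shows that the position responds to the group it carries: replacing 1-methyl-1H-indol-2-yl with naphthalen-2-yl gives a 2.5-fold lower number from compound 3 to compound 4 (0.40 log units; beyond the scatter). The step is modest, but it shows that, on a saturated chain carbon bound to an amine nitrogen in a ring, a group made only of carbon and without a hydrogen-bond acceptor can take the place of one with the same count of heavy atoms without raising the number. Nothing measured here explains why the number falls with this change.

This single step swaps a five-membered aromatic ring containing nitrogen for a six-membered aromatic ring of carbon only, so the compounds shown cannot separate the loss of the nitrogen from the change in ring size. Also open, going by these compounds, is how a smaller phenyl group, or a benzofuran-2-yl group with oxygen in its five-membered ring, would read at this position.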